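This account rests on a few compounds, and the source may have more. Where it says the series, first, only, none or still open, it means among the compounds named here.

In a functional assay on the whole organism (Tail, strain ICR) with Mus musculus as the target, in the tail flick test, with a stated time of 150 min, at a dose of 25 umol/kg by the oral route (on this read-out lower numbers stand for a weaker effect and higher numbers for a stronger effect at the one dose given), compound 1 `NC(=O)CC[C@H](NC(=O)CN(c1ncnc2c1ncn2C1CCCCO1)C1CC1)C(=O)OCc1ccccc1` gives 10.7%, and compound 2 `O=C(CN(c1ncnc2c1ncn2C1CCCCO1)C1CC1)N[C@@H](CO)C(=O)OCc1ccccc1` gives 18.3%; the step of a number 7.6 percentage points higher from compound 1 to compound 2 (within the scatter) does not separate the two, so compound 2 stands together with compound 1 within the scatter. Compound 3 `CC(C)(C)OC(=O)NCCCC[C@H](NC(=O)CN(c1ncnc2c1ncn2C1CCCCO1)C1CC1)C(=O)OCc1ccccc1` differs from compound 2 by 3-((tert-butoxycarbonyl)amino)propyl in place of hydroxy on a saturated chain carbon, two bonds along the chain from an amide-type nitrogen and a carbonyl carbon. Among the measured compounds shown here, the only measured step at this place, a number 7.6 percentage points higher from compound 1 to compound 2 (within the scatter), was within the scatter, and no step of the present kind has been measured, so the expected change a number 3.3 percentage points lower from compound 2 to compound 3 (within the scatter) is none beyond the scatter. Compound 3 is therefore estimated at 15%, between 2% and 35%.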

Compound 3, a percentage reported as activity, at one dose (the size of the read-out at that dose, not a potency): 17.2%
Beside the measured number, compound 3's estimate is 2.2 percentage points below it; low and high end bracket the measured number.
By their numbers in this assay, from the lowest: compounds 1, 3 and 2 (each within the scatter of the next).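

In this assay, 3-((tert-butoxycarbonyl)amino)propyl, with 11 heavy atoms, in place of hydroxy, with 1, on the saturated chain carbon gives a number 1.1 percentage points lower from compound 2 to compound 3 (within the scatter), so even this much larger group does not move the read-out beyond the scatter. Against the carbamoyl chain, 2-((tert-butoxycarbonyl)amino)ethyl gives a number 6.5 percentage points higher from compound 1 to compound 3 (within the scatter), and again the two are not separated. Nothing measured here offers a reason for these results.

As far as these compounds go, whether a free amine at the chain end or a carboxylic acid would separate from these three compounds stays open. So does whether any group at this place changes the read-out beyond the scatter.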